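Sulfonyl substituent variation in a trifluoromethyl hydroxyamide series

The compounds below may be only part of what the source reports. "The series", "measured", "known", "first", "only" and "open" are said of these compounds alone.

Measured compounds:
compound 1 `CC(O)(C(=O)Nc1ccc(S(=O)(=O)c2cccc(F)c2)cc1)C(F)(F)F` — 3400 nM
compound 2 `CC(O)(C(=O)Nc1ccc(C#N)c(S(=O)(=O)c2ccccc2)c1)C(F)(F)F` — 2600 nM

In a functional assay (Cavia porcellus) with sulfonylurea receptors; K-ATP channels (Homo sapiens) as the target (on this read-out higher numbers stand for weaker inhibition and lower numbers for stronger inhibition), compound 1 gives 3400 nM and stands at the top of the two numbers shown. Compound 2 gives 2600 nM in this assay; the gap between the two lies within the scatter, so the pair cannot be told apart on these data. Among the compounds with values here, compound 2 differs from compound 1 in more than one place, and no step between measured compounds that differ in a single place is available, so there is no measured precedent for any single change in this set.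

Compound 3 `CN(c1ccccc1)S(=O)(=O)c1ccc(NC(=O)C(C)(O)C(F)(F)F)cc1` differs from compound 1 in one place only: methyl(phenyl)amino in place of 3-fluorophenyl on a sulfonyl sulfur. Within the data shown here, with no comparable step to draw on, the change is expected to shift this assay little, in neither direction beyond the scatter, with a slight lean toward a higher number. The step from compound 1 to compound 3 is thus estimated as a 1.2-fold higher number from compound 1 to compound 3 (0.07 log units; within the scatter). For compound 3 the estimate in this assay is 4000 nM, expected to fall between 1500 nM and 12000 nM.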

Compound 3, half-maximal inhibitory concentration: 2000 nM
Estimate against measurement, compound 3: 2.0-fold (0.30 log units) above; the range from low to high includes it.
By their numbers in this assay, from the lowest: compounds 3, 2 and 1 (each within the scatter of the next).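

In this assay, within the data shown here, the first single-place step reads a 1.7-fold lower number from compound 1 to compound 3 (0.23 log units; within the scatter), so on these data the sulfonyl sulfur accepts methyl(phenyl)amino in place of 3-fluorophenyl without a resolved shift. The comparison also shows that the read-out stays in the same range when the six-membered aromatic ring of carbon remains present but the group on the sulfonyl sulfur now enters through nitrogen and carries a methyl, with no fluorine left in the group. No measurement beyond the read-out itself bears on what lies behind this small step.

The compounds shown all keep a six-membered aromatic ring of carbon in the group on the sulfonyl sulfur, so it remains open whether the same range holds with a saturated amine such as piperidine, a carboxylic acid or a longer alkyl chain there. Also open, going by these compounds, is which part of the exchange matters, the fluorine, the nitrogen or the methyl, and whether methyl(phenyl)amino behaves alike on a core carrying the nitrile.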